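The compounds below may be only part of what the source reports. "The series", "measured", "known", "first", "only" and "open" are said of these compounds alone.

In a functional assay on MCF7 cells (Homo sapiens) for inhibition, read by sulforhodamine B assay, with a stated time of 48 h (a higher number here means a weaker inhibitor of growth, a lower number a stronger inhibitor of growth), the three measured compounds stand as follows:

- compound 1, `COC(=O)c1sc2cc(C#Cc3ccc(OC)cc3)cnc2c1N`: 460 nM
- compound 2, `COC(=O)c1sc2cc(C#Cc3cccc(N)c3)cnc2c1N`: 10800 nM
- compound 3, `COC(=O)c1sc2cc(C#Cc3cccc(OC)c3)cnc2c1N`: 33400 nM

Compound 2 holds the second-highest number of the three: its nearest neighbour is compound 3, with a 3.1-fold higher number from compound 2 to compound 3 (0.49 log units; beyond the scatter), and its furthest is compound 1, from which it is separated by a 23-fold higher number from compound 1 to compound 2 (1.37 log units; beyond the scatter). Compound 4, `COC(=O)c1sc2cc(C#Cc3ccccc3)cnc2c1N`, has not yet been measured in this assay. It differs from compound 2 in one place: hydrogen in place of amino on an aromatic carbon.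

Among the measured compounds shown here, no measured step removes this group outright. For the measured compounds named here, the only step at the same place is the exchange of amino for methoxy, which gave a 3.1-fold higher number from compound 2 to compound 3 (0.49 log units; beyond the scatter), a modest rise. The two large steps, a 23-fold higher number from compound 1 to compound 2 (1.37 log units; beyond the scatter) and a 73-fold higher number from compound 1 to compound 3 (1.86 log units; beyond the scatter), concern the move of a group from one position of the ring to another and bear only indirectly. The step from compound 2 to compound 4 is therefore expected to be modest, most likely towards a higher number but possibly within the scatter, a 1.5-fold higher number from compound 2 to compound 4 (0.17 log units; within the scatter). Compound 4 is accordingly estimated at 16000 nM, within a range of 4500 nM to 60000 nM.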

Compound 4, concentration for 50% growth inhibition: > 150000 nM
Compound 4 was reported as a limit (the forecaster's own chance of this, stated with the estimate: 5%); middle value at least 9.3-fold (0.97 log units) away from the limit.
By their numbers in this assay, from the lowest: compound 1; then compound 2; then compound 3. At a limit, above all of these: compound 4.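

In this assay compound 4 stands at a limit of the assay, not at a number (> 150000 nM). The earlier compounds shown here only exchanged one substituent on this ring for another, whereas compound 4 shows what happens when the ring carries none: the loss of amino gives the first step below, and the loss of methoxy gives the other two (an at least 13-fold higher number from compound 2 to compound 4 (1.14 log units; beyond the scatter); an at least 4.4-fold higher number from compound 3 to compound 4 (0.65 log units; beyond the scatter); an at least 320-fold higher number from compound 1 to compound 4 (2.51 log units; beyond the scatter)). Among these compounds, then, each substituted ring gives a lower number than the plain phenyl, so even the weak compound 3 retains more activity than compound 4.

Going by these compounds, the full size of these steps stays open, since each rests on a limit. The compounds shown also leave open how a hydroxyl group or a fluorine atom at this place would compare, and how an amino group would fare at the place of the methoxy in compound 1.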